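This account rests on a few compounds, and the source may have more. Where it says the series, first, only, none or still open, it means among the compounds named here.

Compound 1 `CCCOc1ccc(S(=O)(=O)N2CCC(N3CCC(C)CC3)CC2)cc1` gives 452 nM in a functional assay on DLD-1 cells (Homo sapiens) for antiproliferative activity, read by CellTiter-Glo, with a stated time of 72 h; on this read-out lower numbers stand for stronger inhibition and higher numbers for weaker inhibition. Compound 2 `CCc1ccc(S(=O)(=O)N2CCC(N3CCC(C)CC3)CC2)cc1` gives > 5000 nM in this assay, which is a limit of the assay rather than a number.

On the numbers shown, compound 2 thus sits at the limit of > 5000 nM in this assay, at which 1 of the 2 values shown sits, and the one measured step, an at least 11-fold higher number from compound 1 to compound 2 (1.04 log units; beyond the scatter), ends there. Compound 3 `CC1CCN(C2CCN(S(=O)(=O)c3ccc(C(C)C)cc3)CC2)CC1` differs from compound 2 by methyl in place of hydrogen on a saturated chain carbon bound to an aromatic carbon and a saturated chain carbon. The measured step bears on this change only loosely: it swaps ethyl for propoxy rather than adding a methyl to ethyl, so it shows that this group can move the number strongly without saying which way a further methyl would push it. Since compound 2 already stands at the limit, compound 3 is expected to remain close to it, with a step that the limit leaves unreadable from compound 2 to compound 3 that is not expected to exceed the scatter. Compound 3 is therefore estimated at 6000 nM, within a range from 2000 nM to 20000 nM.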

Compound 3, half-maximal inhibitory concentration: 685 nM
For compound 3 the middle estimate is 8.8-fold (0.94 log units) above the measured one; measured number outside the range, below it.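

In this assay, adding one methyl to the saturated chain carbon bound to an aromatic carbon and a saturated chain carbon, which turns ethyl into isopropyl, gives an at least 7.2-fold lower number from compound 2 to compound 3 (0.86 log units; beyond the scatter), so this position answers strongly to a very small change. Compound 2 stands only as a limit of the assay, and the full size of this step therefore cannot be read: the limit of > 5000 nM in this assay, at which 1 of the 3 values shown sits. The step of isopropyl in place of propoxy, a 1.5-fold higher number from compound 1 to compound 3 (0.18 log units; within the scatter), shows that the propoxy group is not needed to reach this level of activity, and that ethyl, not the loss of propoxy as such, goes with the weak result.

As far as these compounds go, whether branching or chain size matters remains open, and a straight propyl group would separate the two. From the compounds shown here alone, whether tert-butyl or cyclopropyl would carry the number further down also stays open.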